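Thiophene for Pyridine on a Diaryl Pyridine Scaffold

The source may report more compounds than this note shows. Statements on the series, on what has been measured and on what is new or still open speak of the compounds shown alone.

Compound 1 `Oc1ccc(-c2cc(-c3cccc(Cl)c3)nc(-c3ccccn3)c2)cc1`: 35200 nM
Compound 2 `Oc1cccc(-c2cc(-c3cccc(Cl)c3)nc(-c3ccccn3)c2)c1`: "not determined" (no result reported)
Compound 3 `Oc1cccc(-c2cc(-c3ccc(Cl)cc3)nc(-c3ccccn3)c2)c1`: 8090 nM

Three compounds share a core that carries a chlorophenyl group, a hydroxyphenyl group and a pyridin-2-yl group. In a functional assay on DU-145 cells (Homo sapiens) for cytotoxicity, read by CCK-8 assay and cell counting, with a stated time of 2 days (on this read-out lower numbers stand for stronger inhibition and higher numbers for weaker inhibition), compound 1 gives 35200 nM. In this assay compound 3 gives 8090 nM. Compound 1 and compound 3 differ in two places at once, so the two values show only the overall spread between them and no single step can be read from them. Compound 2, which carries a 3-chlorophenyl group and a 3-hydroxyphenyl group, has in this assay only the entry "not determined" (no result reported); it therefore stands nowhere on the numbers shown, and its place can only be guessed from compound 1 and compound 3, which sit on either side of it in structure.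

Compound 4 `Oc1cccc(-c2cc(-c3cccc(Cl)c3)nc(-c3cccs3)c2)c1` is made from compound 2 by thiophen-2-yl in place of pyridin-2-yl on an aromatic carbon. Among the compounds with values here, no measured pair shows what such an exchange does on this core, so no step beyond the scatter can be expected in one direction rather than the other; the most that can be said is that the value is likely to fall in the range spanned by compound 1 and compound 3. Compound 4 is therefore estimated at 15000 nM in this assay, with a range from 3000 nM to 60000 nM.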

Compound 4, half-maximal inhibitory concentration: 2650 nM
For compound 4 the middle estimate is 5.7-fold (0.75 log units) above the measured one; measured number below the stated range.
By their numbers in this assay, from the lowest: compound 4; then compound 3; then compound 1.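

No step can be read for thiophen-2-yl in place of pyridin-2-yl: in this assay compound 4 gives 2650 nM while compound 2 has no number, and compound 4 differs from compound 1 and compound 3 in more than one place. Nothing available bears on this result. The compounds shown leave open what this exchange alone does on the shared core.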